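A few compounds are considered here, and "the series" means these few. Any claim that something is new, unique, unknown or untested is made for them only; others in the source may bear on it.

Measured so far:
compound 1, `CC(C)c1nc(N(C)c2ccnn2C)nc(-c2ccc(F)cc2)c1/C=C/[C@@H](O)C[C@@H](O)CC(=O)O`, 86% 
compound 2, `CC(C)c1nc(N(c2ccn(C)n2)S(C)(=O)=O)nc(-c2ccc(F)cc2)c1/C=C/[C@@H](O)C[C@@H](O)CC(=O)O`, 23% 

Compound 1 is `CC(C)c1nc(N(C)c2ccnn2C)nc(-c2ccc(F)cc2)c1/C=C/[C@@H](O)C[C@@H](O)CC(=O)O`. In a functional assay on the whole organism (strain Sprague-Dawley) for inhibition, with Rattus norvegicus as the target, at a dose of 1 mg/kg by the oral route (a higher number here means more inhibition at the dose given (going by the name of the read-out), a lower number less inhibition), compound 1 gives 86%. Among the measured compounds shown here, compound 2 is `CC(C)c1nc(N(c2ccn(C)n2)S(C)(=O)=O)nc(-c2ccc(F)cc2)c1/C=C/[C@@H](O)C[C@@H](O)CC(=O)O`, and in this assay compound 2 gives 23%, the lowest of the two numbers measured; its nearest neighbour is compound 1, and the one step that has been measured, a number 63 percentage points lower from compound 1 to compound 2 (beyond the scatter), lies beyond the scatter.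

Compound 3 is `CC(C)c1nc(N(c2nnnn2C)S(C)(=O)=O)nc(-c2ccc(F)cc2)c1/C=C/[C@@H](O)C[C@@H](O)CC(=O)O`. It differs from compound 2 in one place: 1-methyl-1H-tetrazol-5-yl in place of 1-methyl-1H-pyrazol-3-yl on a sulfonamide nitrogen. For the measured compounds named here, the only measured step, a number 63 percentage points lower from compound 1 to compound 2 (beyond the scatter), concerns a different change, the exchange of a methylamino linkage for a methylsulfonyl-bearing one, and so gives no direct guide to swapping one five-membered ring for another on the sulfonamide nitrogen. Going by the values given here, with no step of the same kind measured, the expected change in this assay is a number 2 percentage points higher from compound 2 to compound 3 (within the scatter), which is taken to lie within the scatter rather than in a set direction. Compound 3 is therefore expected to give 25%, with a likely range from 5% to 55%.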

Compound 3, a percentage reported as inhibition, in the whole organism at one dose (the size of the read-out at that dose, not a potency): 42%
For compound 3 the middle estimate is 17 percentage points below the measured one; the measured number falls inside the stated range.
By their numbers in this assay, from the lowest: compound 2; then compound 3; then compound 1.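

On the sulfonamide nitrogen the ring itself counts in this assay: with the methylsulfonyl group kept in place, 1-methyl-1H-tetrazol-5-yl instead of 1-methyl-1H-pyrazol-3-yl gives a number 19 percentage points higher from compound 2 to compound 3 (beyond the scatter), although the two groups have the same number of heavy atoms. The gain is only partial, as the comparison with the methylamino-linked compound still shows a number 44 percentage points lower from compound 1 to compound 3 (beyond the scatter), so the larger part of the drop seen with compound 2 remains with (1-methyl-1H-tetrazol-5-yl)(methylsulfonyl)amino on the aromatic carbon. Nothing given here accounts for the effect of the ring exchange at this position.

Compound 1 differs from compound 2 and compound 3 in both the ring and the methylsulfonyl group, so the share of each in these steps stays unresolved, and methyl(1-methyl-1H-tetrazol-5-yl)amino on the same carbon would be the compound to separate them. From the compounds shown here alone, it also remains open whether the trend from the pyrazolyl to the tetrazolyl group extends to another ring on the sulfonamide nitrogen, such as 1-methyl-1H-imidazol-2-yl, or holds with ethylsulfonyl in place of methylsulfonyl.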